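The source may hold more compounds than are shown below. What is called first, only, known or untested is meant among the compounds shown, and "the series" means these compounds.

Four compounds share the same core and differ only in the group carried on a saturated chain carbon bound to an oxygen on a saturated carbon and a saturated chain carbon. Compound 1 `OC(CCn1nc2c(Br)c(Br)c(Br)c(Br)c2n1)c1ccccc1` gives 21% in a functional assay on CCRF-CEM cells (Homo sapiens) for antiproliferative activity, read by MTT assay, with a stated time of 24 h, tested at 100 uM; a higher number here means a weaker effect of the compound at the concentration tested, a lower number a stronger effect. Compound 2 `OC(CCn1nc2c(Br)c(Br)c(Br)c(Br)c2n1)c1ccc(Br)cc1` gives 0% in this assay, and compound 3 `CC(O)CCn1nc2c(Br)c(Br)c(Br)c(Br)c2n1` gives 3%. Among these three numbers compound 3 stands second highest; its nearest neighbour is compound 2, whose value lies within the usual scatter of it, and its furthest is compound 1. The step of a number 18 percentage points lower from compound 1 to compound 3 (beyond the scatter) lies beyond the scatter, while the step of a number 3 percentage points higher from compound 2 to compound 3 (within the scatter) does not.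

Compound 4 `OC(CCn1nc2c(Br)c(Br)c(Br)c(Br)c2n1)c1ccc(Cl)cc1` is not yet measured. It differs from compound 3 by 4-chlorophenyl in place of methyl on a saturated chain carbon bound to an oxygen on a saturated carbon and a saturated chain carbon. The step from compound 1 to compound 2, a number 21 percentage points lower from compound 1 to compound 2 (beyond the scatter), and the step of a number 3 percentage points higher from compound 2 to compound 3 (within the scatter) bear on this change most closely, since compound 4 carries a halogen on the phenyl much like compound 2. Because a number 3 percentage points higher from compound 2 to compound 3 (within the scatter) was within the scatter, only a small step is expected for compound 4, as a number 1 percentage points lower from compound 3 to compound 4 (within the scatter). Compound 4 is therefore estimated at 2%, within 0% to 14%.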

Compound 4, a percentage reported as activity, at one concentration (the size of the read-out at that concentration, not a potency): 0%
Estimate against measurement, compound 4: 2 percentage points above; the range from low to high includes it.
By their numbers in this assay, from the lowest: compounds 2, 4 and 3 (each within the scatter of the next); then compound 1.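

In this assay, exchanging bromo for chloro on the aromatic carbon gives no change at the digits printed from compound 2 to compound 4 (within the scatter) and so shows that this halogen can change without a visible shift in the read-out. The 4-chlorophenyl group also gives a number 21 percentage points lower from compound 1 to compound 4 (beyond the scatter) against the plain phenyl, so the earlier step seen with bromo is now matched with a second halogen. Exchanging the small methyl for this much larger group gives a number 3 percentage points lower from compound 3 to compound 4 (within the scatter) in this same position, but no measurement here explains why these groups read alike while the plain phenyl stands apart.

As far as these compounds go, it remains open whether an amine or a carboxylic acid on the phenyl ring, or a longer chain in place of methyl, would read like compound 4 or like compound 1. Readings this close together at one concentration also leave any real difference among compound 2, compound 3 and compound 4 unresolved.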